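Inverting One Ring Stereocentre in a Histamine Receptor Binder

The compounds below may be only part of what the source reports. "The series", "measured", "known", "first", "only" and "open" are said of these compounds alone.

Compound 2 `Cc1cc(N2CC[C@@H](N3CCC[C@@H]3C)C2)ccc1NC(=O)C1CCOCC1` gives 3.9 nM in an assay on CHO cells for displacement of a labelled ligand from histamine receptor H3 (Macaca mulatta) (a lower number here means a stronger inhibitor, a higher number a weaker inhibitor), the lower of the two numbers measured, although its gap to compound 1 `Cc1cc(N2CC[C@H](N3CCC[C@@H]3C)C2)ccc1NC(=O)C1CCCO1`, which gives 7.33 nM, lies within the scatter. Compound 3 `Cc1cc(N2CC[C@H](N3CCC[C@@H]3C)C2)ccc1NC(=O)C1CCOCC1` has not yet been measured. It keeps every atom and bond of compound 2 and differs only in configuration: the two compounds have the same atoms and bonds and differ only in configuration as drawn: 1 of 2 stereo elements differ; a stereocentre at a saturated ring carbon is drawn R in compound 2 and S in compound 3. Within the data shown here, no measured pair isolates such an inversion, so the expected step in this assay is small, leaning toward a higher number, and may well stay within the scatter. Compound 3 is therefore estimated at 6 nM, with a range of 2 nM to 20 nM, corresponding to a step of a 1.5-fold higher number from compound 2 to compound 3 (0.19 log units; within the scatter).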

Compound 3, inhibition constant: 0.97 nM
For compound 3 the middle estimate is 6.2-fold (0.79 log units) above the measured one; measured number below the stated range.
By their numbers in this assay, from the lowest: compound 3; then compounds 2 and 1 (each within the scatter of the next).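

In this assay, the configuration at this saturated ring carbon counts: inverting it from R to S gives a 4.0-fold lower number from compound 2 to compound 3 (0.60 log units; beyond the scatter). That step can be pinned on this one stereocentre because nothing else changes: the fact that compounds 2 and 3 differ only in the configuration as drawn

With the S configuration kept, oxan-4-yl in place of oxolan-2-yl on the carbonyl carbon gives a 7.6-fold lower number from compound 1 to compound 3 (0.88 log units; beyond the scatter), so the group on the carbonyl counts too. As far as these compounds go, whether oxolan-2-yl would respond to the same inversion remains open. So does how an amine such as piperidin-4-yl on that carbonyl carbon would behave with either configuration.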